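This account rests on a few compounds, and the source may have more. Where it says the series, first, only, none or still open, it means among the compounds named here.

Among the measured compounds shown here, in a functional assay on Ehrlich cells (Mus musculus) for inhibition (a higher number here means a weaker inhibitor, a lower number a stronger inhibitor), compound 2 `O=C(O)c1cnc2cc(O)ccc2c1O` gives 912000 nM as the lower of the two numbers so far, and compound 1 `O=C(O)c1ccc2c(O)c(C(=O)O)cnc2c1` gives 5750000 nM as the higher. Compound 3 `COc1ccc2c(O)c(C(=O)O)cnc2c1` differs from compound 2 by one change, methyl in place of hydrogen on an oxygen on an aromatic ring in the form of methyl in place of hydrogen on an oxygen on an aromatic ring, which turns hydroxy to methoxy. For the measured compounds named here, the only measured step is a 6.3-fold lower number from compound 1 to compound 2 (0.80 log units; beyond the scatter) and it put hydroxy in place of carboxy, so it says little directly about adding a methyl. No step beyond the scatter is therefore expected in this assay here. The estimated step is a 1.1-fold lower number from compound 2 to compound 3 (0.06 log units; within the scatter) and its direction remains uncertain. For compound 3 the estimated value is 800000 nM with an expected range from 280000 nM to 2300000 nM around it.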

Compound 3, half-maximal inhibitory concentration: 525000 nM
The estimate for compound 3 lay 1.5-fold (0.18 log units) above the measured number; the measured number falls inside the stated range.
By their numbers in this assay, from the lowest: compounds 3 and 2 (each within the scatter of the next); then compound 1.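

In this assay methyl in place of hydrogen on an oxygen on an aromatic ring gives a 1.7-fold lower number from compound 2 to compound 3 (0.24 log units; within the scatter) and so this hydrogen can be replaced without a step beyond the scatter. Swapping the carboxy for methoxy gives an 11-fold lower number from compound 1 to compound 3 (1.04 log units; beyond the scatter) and so hydroxy and methoxy both stand on the lower side of carboxy here. No evidence at hand bears on the cause of these steps. From the compounds shown here alone, whether a longer chain such as ethyl on this oxygen would be accepted as well stays open, and so does the effect of an amine at this place.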